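Chain-linked prolinamide piperazines at the serotonin 7 receptor

The source may report more compounds than this note shows. Statements on the series, on what has been measured and on what is new or still open speak of the compounds shown alone.

Measured compounds:
compound 1, `NC(=O)[C@@H]1CCCN1C(=O)CCCCCN1CCN(c2cccc(Cl)c2)CC1`, 478 nM
compound 2, `NC(=O)[C@@H]1CCCN1C(=O)CCCCN1CCN(c2noc3ccccc23)CC1`, 108 nM

In an assay on HEK293 cells for displacement of a labelled ligand from 5-hydroxytryptamine receptor 7 (Homo sapiens), with a stated time of 1 h (a higher number here means a weaker inhibitor, a lower number a stronger inhibitor), compound 1 gives 478 nM, the highest of the two numbers recorded. Its nearest neighbour is compound 2, which in this assay gives 108 nM, a gap that lies beyond the usual scatter of the measurement.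

Compound 3, `NC(=O)[C@@H]1CCCN1C(=O)CCCCCN1CCN(c2noc3ccccc23)CC1`, has not yet been measured. It is derived from compound 1 by the change (a group of 9 heavy atoms (7 carbon, 1 nitrogen, 1 oxygen; one five-membered aromatic ring with 2 hetero atoms, one six-membered aromatic ring of carbon only) in place of a group of 7 heavy atoms (6 carbon, 1 chlorine; one six-membered aromatic ring of carbon only), on an amine nitrogen in a ring). Among the measured compounds shown here, no measured pair isolates this change, so its size is not known from the data at hand. Compound 2 shows that a lower number than compound 1 is reached within this series, so the expectation for compound 3 is a step toward a lower number, a 4.8-fold lower number from compound 1 to compound 3 (0.68 log units; beyond the scatter), beyond the scatter. Compound 3 is estimated at 100 nM, with a range from 30 nM to 330 nM.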

Compound 3, inhibition constant: 50 nM
Estimate against measurement, compound 3: 2.0-fold (0.30 log units) above, and the stated range covers the measured number.
By their numbers in this assay, from the lowest: compound 3; then compound 2; then compound 1.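

With the chain held the same, replacing 3-chlorophenyl with the two-ring group on the amine nitrogen of the six-membered ring gives a 9.6-fold lower number from compound 1 to compound 3 (0.98 log units; beyond the scatter) in this assay. Among the compounds shown here, this is the first direct reading of this change at this position, as compound 1 and compound 2 differ in more than one place. The step is measured on this one pair only, and nothing at hand accounts for its size.

The compounds shown leave open whether a step of this size would recur on a shorter or a longer chain. They also leave open how a plain phenyl or a pyridine ring on the same nitrogen would compare, and what a carboxylic acid in place of the primary amide would do to the number.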